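The compounds below may be only part of what the source reports. "The series", "measured", "known", "first", "only" and "open" are said of these compounds alone.

Compound 1 `Cc1cnc(NCC2(c3ccccc3)CCC2)c(=O)n1CC(=O)NCc1ccc2c(N)noc2c1` is the compound whose half-life this piece follows. In an in vivo ADME assay on the whole organism with Canis familiaris (Canis lupus familiaris) as the target (on this read-out lower numbers stand for a shorter-lived compound and higher numbers for a longer-lived compound), compound 1 gives 1.95 h. Among the measured compounds shown here, the only other compound with a number here is compound 2 `Cc1ccc(NS(=O)(=O)Cc2ccccc2)c(=O)n1CC(=O)NCc1ccc2[nH]ncc2c1`, which shares the central ring and the chain carrying an amide with compound 1 but differs at several places at once. In this assay compound 2 gives 0.6 h. For the measured compounds named here, of the two numbers known, compound 1 stands highest, and its gap to compound 2 lies beyond the usual scatter of such measurements. Because compound 2 differs from compound 1 in more than one place, these two values alone do not show which part of the structure carries that gap.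

The compound to be measured next is compound 3 `Cc1cnc(NCC2(c3ccc(F)cc3)CC2)c(=O)n1CC(=O)NCc1ccc2c(N)noc2c1`. It differs from compound 1 in one place: 1-(4-fluorophenyl)cyclopropyl in place of 1-phenylcyclobutyl on a saturated chain carbon bound to a nitrogen on an aromatic ring. Neither ring nor the fluorine adds a hydrogen-bond donor or acceptor, and the number of heavy atoms stays the same. Going by the values given here, no pair of measured compounds here shows what such a change does to the half-life, so the step from compound 1 to compound 3 is expected to stay within the scatter, a 1.0-fold higher number from compound 1 to compound 3 (0.01 log units; within the scatter). For compound 3 the half-life in this assay is estimated at 2 h, within a range from 1 h to 4 h.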

Compound 3, half-life: 2.17 h
For compound 3 the middle estimate is 1.1-fold (0.04 log units) below the measured one; the measured number falls inside the stated range.
By their numbers in this assay, from the lowest: compound 2; then compounds 1 and 3 (each within the scatter of the next).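

Among the compounds shown here, the step from 1-phenylcyclobutyl to 1-(4-fluorophenyl)cyclopropyl, on a saturated chain carbon bound to a nitrogen on an aromatic ring, is the first comparison here in which only one place differs, and in this assay it reads a 1.1-fold higher number from compound 1 to compound 3 (0.05 log units; within the scatter). At this position, then, a three-membered ring in place of a four-membered one, together with a fluorine on the aromatic ring, gives a half-life that cannot be told apart from that of compound 1. Nothing measured here bears on what lies behind this result.

This single step changes the ring size and brings in the fluorine together, so the compounds shown cannot tell whether each change alone would leave the half-life in the same range or whether the two offset each other, a question that 1-phenylcyclopropyl or 1-(4-fluorophenyl)cyclobutyl at this place could settle. Also open, on these data alone, is how the half-life would respond to a different kind of group here, such as an amine or a carboxylic acid.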